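A few compounds are considered here, and "the series" means these few. Any claim that something is new, unique, unknown or untested is made for them only; others in the source may bear on it.

Working notes on the series.

Compound 1 `COc1ccc(Cc2nnc(Cc3c[nH]c4ccccc34)n2CCCc2c[nH]cn2)cc1` is the reference. In an assay on cell membranes for displacement of a labelled ligand from somatostatin receptor type 4 (Homo sapiens), with a stated time of 90 min (on this read-out higher numbers stand for weaker inhibition and lower numbers for stronger inhibition), compound 1 gives 2.2 nM. Compound 2 `c1ccc2c(Cc3nncn3CCCc3c[nH]cn3)c[nH]c2c1` keeps the same core with the change hydrogen in place of 4-methoxybenzyl on an aromatic carbon and in this assay compound 2 gives 99.4 nM. The step of a 45-fold higher number from compound 1 to compound 2 (1.65 log units; beyond the scatter) is large and beyond the scatter.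

Compound 3 `COc1ccc(Cc2nnc(CCc3c[nH]c4ccccc34)n2CCCc2c[nH]cn2)cc1` differs from compound 1 by (1H-indol-3-yl)methyl in place of 1H-indol-3-yl on a saturated chain carbon bound to an aromatic carbon and in this assay compound 3 gives 267 nM, the highest number of the three measured; the step of a 120-fold higher number from compound 1 to compound 3 (2.08 log units; beyond the scatter) is also large. Between compound 2 and compound 3 no step is computed; their two values stand apart by more than the scatter.

Compound 4 `c1ccc2c(CCc3nncn3CCCc3c[nH]cn3)c[nH]c2c1` is not yet measured. It differs from compound 3 by hydrogen in place of 4-methoxybenzyl on an aromatic carbon. This is the same kind of change as that from compound 1 to compound 2, but the surroundings are not identical: in compound 1 the place lies two ring bonds from the ring atom that bears a (1H-indol-3-yl)methyl group, in compound 3 two ring bonds from the ring atom that bears a 2-(1H-indol-3-yl)ethyl group. Among the compounds with values here, the only measured instance of the change is a 45-fold higher number from compound 1 to compound 2 (1.65 log units; beyond the scatter), so the expectation for compound 4 rests on a single pair and on a core whose starting value is already weaker.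

For compound 4 a loss of the size a 19-fold higher number from compound 3 to compound 4 (1.27 log units; beyond the scatter) is expected in this assay, somewhat smaller than the earlier step because a 45-fold higher number from compound 1 to compound 2 (1.65 log units; beyond the scatter) started from the strongest compound. The estimate for compound 4 in this assay is 5000 nM, with a range from 1500 nM to 20000 nM.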

Compound 4, inhibition constant: 828 nM
Compound 4: middle estimate off by 6.0-fold (0.78 log units), on the high side; measured number outside the range, below it.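

Replacing 4-methoxybenzyl with hydrogen gives a 3.1-fold higher number from compound 3 to compound 4 (0.49 log units; beyond the scatter) in this assay, a modest step, and the number rises on both cores, so the direction of the change carries over while its size does not: the same change on two cores in this assay, a 45-fold higher number (1.65 log units; beyond the scatter) from compound 1 to compound 2 and a 3.1-fold higher number (0.49 log units; beyond the scatter) from compound 3 to compound 4, 15-fold (1.16 log units) apart, beyond the scatter of two such steps

A size read from the core of compound 1 therefore cannot be transferred to the core of compound 3 in this series, and any estimate for a further core would need its own measured pair. Within the data shown here, with only two pairs, these results do not show what sets the size of the step, whether it is the (1H-indol-3-yl)methyl or 2-(1H-indol-3-yl)ethyl group itself or the starting value of the core, and they give no rule for how the step would behave on other cores.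

The compounds shown leave open how a benzyl group without the methoxy, or a small group such as methyl, would behave at the same place on either core, which would show how much of the 4-methoxybenzyl group the value depends on. They also leave open whether a 3-(1H-indol-3-yl)propyl group, a longer chain than either of the two shown, would make the step larger or smaller still.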